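The source may hold more compounds than are shown below. What is called first, only, known or untested is meant among the compounds shown, and "the series" means these compounds.

Measured in an ADME assay on microsomes from liver (Rattus norvegicus) for metabolic stability, with a stated time of 10 min, tested at 0.5 uM; on this read-out higher numbers stand for a more stable compound and lower numbers for a less stable compound:
- compound 1 `Cc1onc(-c2ccccc2)c1[C@@H]1C[C@@](C)(c2ccc(F)cc2F)N=C(N)S1`: 13%
- compound 2 `Cc1onc(-c2ccc(F)cc2)c1[C@@H]1C[C@@](C)(c2ccc(F)cc2F)N=C(N)S1`: 35%
- compound 3 `Cc1noc(-c2ccccc2)c1[C@@H]1C[C@@](C)(c2ccc(F)cc2F)N=C(N)S1`: 20%

Compound 3 sits within the scatter of compound 1 and beyond the scatter under compound 2. Compound 4 `Cc1nocc1[C@@H]1C[C@@](C)(c2ccc(F)cc2F)N=C(N)S1` carries hydrogen in place of phenyl on an aromatic carbon of compound 3: hydrogen in place of phenyl on an aromatic carbon. Within the data shown here, the one measured step on a phenyl, a number 22 percentage points higher from compound 1 to compound 2 (beyond the scatter), came with fluoro in place of hydrogen on an aromatic carbon. It bears only indirectly, since here the whole phenyl goes. Among the measured compounds shown here, no measured step removes a phenyl, so the range stays wide. The expected change in this assay is upward and of similar size: a number 22 percentage points higher from compound 3 to compound 4 (beyond the scatter). Compound 4 is estimated at 42%, with an expected range of 20% to 68%.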

Compound 4, percent of the compound remaining: 77%
The estimate for compound 4 lay 35 percentage points below the measured number; measured number above the stated range.
By their numbers in this assay, from the lowest: compounds 1 and 3 (each within the scatter of the next); then compound 2; then compound 4.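

On the aromatic carbon next to the ring oxygen, hydrogen in place of phenyl gives a number 57 percentage points higher from compound 3 to compound 4 (beyond the scatter) in this assay. Among these compounds, the phenyl at this position therefore weighs far more on this read-out than the earlier compounds could show, and the stability of compound 4 needs no aromatic substituent there. No evidence at hand accounts for the step.

Open, as far as these compounds go, is whether any group other than hydrogen on this carbon, such as methyl, an amine or a carboxylic acid, holds the number near that of compound 4 . Also open, from the compounds shown here alone, is whether the same removal gives a similar step on the isomeric ring of compound 1 .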